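The source may hold more compounds than are shown below. What is called first, only, known or untested is meant among the compounds shown, and "the series" means these compounds.

Compound 1 `Cc1cc(NC(=O)Nc2ccc(F)cc2)c2ccccc2n1`: 3700 nM
Compound 2 `Cc1cc(NC(=O)Nc2cccc(F)c2)c2ccccc2n1`: 100 nM
Compound 3 `COC(=O)c1ccc(NC(=O)Nc2cc(C)nc3ccccc23)cc1`: 1200 nM

These three compounds were measured in a physicochemical assay for solubility, at pH 7.4; a higher number here means a more soluble compound, a lower number a less soluble compound. Compound 4 `COC(=O)c1cccc(NC(=O)Nc2cc(C)nc3ccccc23)c1` is not yet measured in this assay. Compound 2 differs from compound 1 in the following way: 3-fluorophenyl in place of 4-fluorophenyl on an amide-type nitrogen. That rearrangement gave a 37-fold lower number from compound 1 to compound 2 (1.57 log units; beyond the scatter), so compound 2 stands lowest of the three, with compound 3 nearest to it and compound 1 furthest away. Compound 3 differs from compound 1 as follows: methoxycarbonyl in place of fluoro on an aromatic carbon. This step gave a 3.1-fold lower number from compound 1 to compound 3 (0.49 log units; beyond the scatter).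

Compound 4 differs from compound 2 as follows: methoxycarbonyl in place of fluoro on an aromatic carbon. The group that leaves and the group that enters are the same as from compound 1 to compound 3, but the place is not the same word for word: in compound 3 the new group is para to a large group, while in compound 4 it is meta to a large group. For the measured compounds named here, it is therefore the same kind of change, not the same change, and only one measured example of it exists here.

Compound 4 is expected to show a 2.5-fold lower number from compound 2 to compound 4 (0.40 log units; beyond the scatter), a step of about the size of a 3.1-fold lower number from compound 1 to compound 3 (0.49 log units; beyond the scatter), resting on that single measured step. Compound 4 is estimated at 40 nM in this assay, with a likely range from 10 nM to 200 nM.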

Compound 4, solubility: 600 nM
Compound 4: middle estimate off by 15-fold (1.18 log units), on the low side; measured number outside the range, above it.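

In this assay, putting methoxycarbonyl in place of fluoro did not act the same way at the two places: with the new group para to a large group the result was a 3.1-fold lower number from compound 1 to compound 3 (0.49 log units; beyond the scatter), but with it meta to a large group the result was a 6.0-fold higher number from compound 2 to compound 4 (0.78 log units; beyond the scatter). Both steps lie beyond the scatter and run in opposite directions, so in this pair the direction of the step measured at one place did not carry over to the other, and a step measured at one place is a poor guide to the other. Two steps cannot establish a rule for the series, and nothing shown here explains why the direction differs.

The compounds shown hold only fluoro and methoxycarbonyl on this ring, each at only these two places, so it remains open whether a group such as a carboxylic acid or an amine would also give steps of opposite direction at the two places. It also remains open whether the opposite steps seen here would recur with other pairs of groups, since only this one exchange can be followed at both places.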